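Cytotoxicity on BJ cells across a shared core

A few compounds are considered here, and "the series" means these few. Any claim that something is new, unique, unknown or untested is made for them only; others in the source may bear on it.

In an ADME assay on BJ cells (Homo sapiens), read by MTT assay, with a stated time of 3 days (on this read-out higher numbers stand for weaker inhibition and lower numbers for stronger inhibition), compound 1 `CNc1ncnc2[nH]cc(Sc3cccs3)c12` gives 132000 nM. Compound 2 `Nc1ncnc2[nH]cc(Sc3cccs3)c12` is reported only at the limit > 150000 nM. Compound 2 thus stands at the limit of > 150000 nM in this assay, at which 1 of the 2 values shown sits. For the measured compounds named here, the step of an at least 1.1-fold higher number from compound 1 to compound 2 (0.05 log units; that floor lies within the scatter) is the sole measured step, and it concerns a nitrogen on an aromatic ring rather than the place altered in compound 3 `c1coc(-c2ncnc3[nH]cc(Sc4cccs4)c23)c1`; the change is furan-2-yl in place of amino on an aromatic carbon. Going by the values given here, no measured step bears on furan-2-yl in place of amino. The expected step of an at least 1.6-fold lower number from compound 2 to compound 3 (0.22 log units; that floor lies within the scatter) is set at none beyond the scatter, with some allowance for a lower number. Compound 3 is estimated at 90000 nM, within 30000 nM to 150000 nM.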

Compound 3, half-maximal inhibitory concentration: 22100 nM
Estimate against measurement, compound 3: 4.1-fold (0.61 log units) above, and the stated range ends above it.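

In this assay, replacing the nitrogen substituent on this aromatic carbon with furan-2-yl gives a step beyond the scatter, which the change on the nitrogen alone did not: a 6.0-fold lower number from compound 1 to compound 3 (0.78 log units; beyond the scatter). The step from the amino compound points the same way, an at least 6.7-fold lower number from compound 2 to compound 3 (0.83 log units; beyond the scatter), but it is only a floor. Compound 2 is held only at a limit of the assay: the limit of > 150000 nM in this assay, at which 1 of the 3 values shown sits.

As far as these compounds go, it remains open whether the lower number is specific to furan-2-yl or also holds for another ring on this carbon, such as phenyl or morpholine. From the compounds shown here alone, a longer alkylamine at this place is also open.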